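The source may report more compounds than this note shows. Statements on the series, on what has been measured and on what is new or still open speak of the compounds shown alone.

Working notes on the series.

Compound 3 `Cc1cc(C)c(S(=O)(=O)N[C@@H](CNC(=O)CO[C@@H]2C[C@@H](CNc3ccccn3)N(CCCc3ccccc3)C2)C(=O)O)c(C)c1` gives the highest number of the three measured in an assay on a protein complex for inhibition of integrin alpha-5/beta-1 (Homo sapiens), read by ELISA; on this read-out higher numbers stand for weaker inhibition and lower numbers for stronger inhibition: compound 3 reads 670 nM. Going by the values given here, compound 1 `Cc1cc(C)c(C(=O)N[C@@H](CNC(=O)CO[C@@H]2C[C@@H](CNc3ccccn3)N(C(=O)OCc3ccccc3)C2)C(=O)O)c(C)c1` reads 3.5 nM in this assay and compound 2 `COc1ccnc(NC[C@@H]2C[C@@H](OCC(=O)NC[C@H](NS(=O)(=O)c3c(C)cc(C)cc3C)C(=O)O)CN2C(=O)OCc2ccccc2)c1` reads 1.1 nM; both gaps to compound 3 are far beyond the usual scatter, but neither pair differs from compound 3 in one place only, so no single step can be drawn from them. What the values show is that compounds 1 and 2, which each carry a benzyl carbamate on the ring nitrogen of the shared core, sit low, while compound 3, with 3-phenylpropyl on that nitrogen, sits high.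

Compound 4 `Cc1cc(C)c(S(=O)(=O)N[C@@H](CNC(=O)CO[C@@H]2C[C@@H](CNc3ccccn3)N(C(=O)CCc3ccccc3)C2)C(=O)O)c(C)c1` is the unmeasured partner of compound 3. The change is phenethylcarbonyl in place of 3-phenylpropyl on an amine nitrogen in a ring. Nothing else moves; the sulfonamide acid part of compound 3 is kept.

The expectation rests on the carbamate-bearing compounds: compound 1 reads 3.5 nM in this assay and compound 2 reads 1.1 nM. With a carbonyl again on the ring nitrogen, a large step downward is expected for compound 4, a 45-fold lower number from compound 3 to compound 4 (1.65 log units; beyond the scatter). Compound 4 is estimated at 15 nM in this assay, with a range from 2 nM to 100 nM.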

Compound 4, half-maximal inhibitory concentration: 25 nM
Estimate against measurement, compound 4: 1.7-fold (0.22 log units) below, within the range that was stated.
By their numbers in this assay, from the lowest: compound 2; then compound 1; then compound 4; then compound 3.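

Going by these compounds alone, the step of a 27-fold lower number from compound 3 to compound 4 (1.43 log units; beyond the scatter) in this assay is the first comparison that changes only one place, the amine nitrogen in the ring, and it is large and beyond the scatter. Until now, the link between a carbonyl on this nitrogen and a low number rested on compounds that also differed elsewhere; here the link holds with the sulfonamide acid part of compound 3 kept, and the leaving and entering groups have the same carbon count and the same aromatic ring, while phenethylcarbonyl adds the carbonyl. No measurement available here accounts for the size of this step.

As far as these compounds go, whether the carbonyl is enough on its own stays open, since a single pair cannot separate it from the other differences between the two chains. Also open, from the compounds shown here alone, is how a urea, a sulfonamide or a phenylacetyl group on the same nitrogen would read in this assay against compound 4 at 25 nM.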